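Trifluoromethyl in place of chloro: expected electroshock dose

A few compounds are considered here, and "the series" means these few. Any claim that something is new, unique, unknown or untested is made for them only; others in the source may bear on it.

Measured so far:
compound 1 `CC(C(=O)NCc1cccc(Cl)c1)N1C(=O)CCC1=O`: 82 mg/kg
compound 2 `CC(C(=O)NCc1ccc(Cl)cc1)N1C(=O)CCC1=O`: 91.8 mg/kg

In a functional assay on the whole organism (strain Albino Swiss CD1) with Mus musculus as the target, in the maximal electroshock model (on this read-out lower numbers stand for an effect already at smaller amounts and higher numbers for an effect only at larger amounts of compound), compound 1 carries the lower of the two numbers, but compound 2 lies within the scatter of it, so no order between them is claimed. Compound 3 `CC(C(=O)NCc1cccc(C(F)(F)F)c1)N1C(=O)CCC1=O` differs from compound 1 by trifluoromethyl in place of chloro on an aromatic carbon. Within the data shown here, no measured pair covers such a change, so in this assay a step no larger than the scatter is expected, in either direction. For compound 3 the estimated value in this assay is 80 mg/kg, with a range from 40 mg/kg to 160 mg/kg. This corresponds to an expected step of a 1.0-fold lower number from compound 1 to compound 3 (0.01 log units; within the scatter).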

Compound 3, dose for half-maximal effect: 92.4 mg/kg
The estimate for compound 3 lay 1.2-fold (0.06 log units) below the measured number; the measured number falls inside the stated range.
By their numbers in this assay, from the lowest: compounds 1, 2 and 3 (each within the scatter of the next).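

Within this assay trifluoromethyl in place of chloro on an aromatic carbon, meta to a large group, gives a 1.1-fold higher number from compound 1 to compound 3 (0.05 log units; within the scatter) and so does not separate the two groups on this read-out. Among these compounds, at this place 4 heavy atoms enter for 1 without a step beyond the scatter, the first measured step for this change. Nothing measured here bears on the reason for this result.

Open, going by these compounds, is whether an amine, a carboxylic acid or a methoxy group at this place would shift the dose beyond the scatter. Also open, on these data alone, is what a longer chain elsewhere on the shared core would do.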